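Changing the aromatic group on a shared core

The source may report more compounds than this note shows. Statements on the series, on what has been measured and on what is new or still open speak of the compounds shown alone.

Values measured in a functional assay on LoVo cells (Homo sapiens) for inhibition, read by MTT assay, with a stated time of 24 h; a higher number here means a weaker inhibitor, a lower number a stronger inhibitor
Compound 1 `CC1(C)[C@H]2CC[C@]1(C)N(Cc1cn(-c3ccccc3Cl)nn1)C(=O)C2` gives 190 nM
Compound 2 `COc1ccccc1-n1cc(CN2C(=O)C[C@@H]3CC[C@@]2(C)C3(C)C)nn1` gives 70 nM

Of these two compounds, compound 2 has the lower number and is therefore the stronger inhibitor, and its gap to compound 1 lies beyond the scatter. Compound 3 `CC1(C)[C@H]2CC[C@]1(C)N(Cc1cn(-c3cccc(O)c3)nn1)C(=O)C2` keeps the shared core but carries 3-hydroxyphenyl in place of 2-methoxyphenyl on an aromatic nitrogen. For the measured compounds named here, only one measured step bears on this change. Putting methoxy in place of chloro on an aromatic carbon gave a 2.7-fold lower number from compound 1 to compound 2 (0.43 log units; beyond the scatter) and was modest but beyond the scatter. That step shows that a change on this aromatic group can shift the number in this assay by a modest amount. Going by the values given here, no measured compound carries 3-hydroxyphenyl, so the direction is uncertain. Among the compounds with values here, since compound 2 holds the lower of only two numbers, a modest move upward is the more likely outcome. The expected change is a 2.0-fold higher number from compound 2 to compound 3 (0.30 log units; within the scatter) and remains a rough estimate. Compound 3 is expected at 140 nM (estimated range 40 nM to 450 nM).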

Compound 3, half-maximal inhibitory concentration: 410 nM
Compound 3: middle estimate off by 2.9-fold (0.47 log units), on the low side; low and high end bracket the measured number.
By their numbers in this assay, from the lowest: compound 2; then compound 1; then compound 3.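

In this assay, 3-hydroxyphenyl on the aromatic nitrogen gives a 5.9-fold higher number from compound 2 to compound 3 (0.77 log units; beyond the scatter) and also a 2.2-fold higher number from compound 1 to compound 3 (0.33 log units; beyond the scatter), so this is the first change shown at this position that makes the inhibitor weaker, and compound 3 is the weakest of the three. The position therefore moves the number in both directions, and the choice of group on this aromatic ring matters in this assay. The change from compound 2 to compound 3 alters more than one feature of the group at once: the oxygen's methyl is lost, the oxygen sits at 3 rather than 2 on the ring, and the hydrogen-bond donors go from 0 to 1. Nothing available explains why the number rises.

On these data alone, what stays open is whether the rise follows the free hydroxyl or its place on the ring, which 2-hydroxyphenyl and 3-methoxyphenyl would help to separate. As far as these compounds go, it is also open how a group such as an amine or a carboxylic acid on this ring would shift the number.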